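Working notes on a cytotoxicity series

This account rests on a few compounds, and the source may have more. Where it says the series, first, only, none or still open, it means among the compounds named here.

Compound 1 `Cc1nc(Nc2cccc(Cl)c2)sc1C(=O)/C=C/c1ccccc1`. In a functional assay on PC-3 cells (Homo sapiens) for cytotoxicity, read by MTT assay (a higher number here means a weaker inhibitor, a lower number a stronger inhibitor), compound 1 gives > 25000 nM; this is a limit of the assay, not a number.
Compound 2 `Cc1ccc(Nc2nc(C)c(C(=O)/C=C/c3ccc(Cl)cc3)s2)cc1`. In this assay compound 2 gives > 25000 nM, again a limit of the assay.
Compound 3 `COc1cc(/C=C/C(=O)c2sc(Nc3cccc(Cl)c3)nc2C)cc(OC)c1OC`. In this assay compound 3 gives > 25000 nM, also a limit of the assay.

Compound 3 thus has no number of its own in this assay; it stands at the limit, and every value recorded so far sits there as well (the limit of > 25000 nM in this assay, at which 3 of the 3 values shown sit). For the measured compounds named here, no pair of measured compounds differs in a single place, so no measured step is available to lean on.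

Compound 4 `COc1cc(/C=C/C(=O)c2sc(Nc3ccc(C)cc3)nc2C)cc(OC)c1OC` differs from compound 3 in one place: 4-methylphenyl in place of 3-chlorophenyl on a nitrogen on an aromatic ring. Going by the values given here, with every value in this assay resting at the limit (the limit of > 25000 nM in this assay, at which 3 of the 3 values shown sit), nothing among the measured compounds points to a gain from this change. The step expected from compound 3 to compound 4 is a step that the limit leaves unreadable from compound 3 to compound 4, that is, nothing beyond the scatter. Compound 4 is expected to give about 35000 nM in this assay, within a range from 8000 nM to 150000 nM, and most probably the assay will again report only a limit.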

Compound 4, half-maximal inhibitory concentration: > 25000 nM
Compound 4: only a limit was reported; the forecaster's own chance of this, stated with the estimate: 75%; the middle value is on the limit's open side.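

Compound 4 gives > 25000 nM in this assay, a limit of the assay and not a number. No step can be read between compound 3 and compound 4, since both rest at the limit: the limit of > 25000 nM in this assay, at which 4 of the 4 values shown sit.

The compounds shown leave open whether any change to the shared core gives a measurable value in this assay.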